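The source may report more compounds than this note shows. Statements on the series, on what has been measured and on what is new or still open speak of the compounds shown alone.

Compound 3 `Cc1ccc2[nH]c(C(=O)N[C@H]3CCN(S(=O)(=O)N(C)C)C[C@@H]3C(=O)NCCN(C)C)cc2c1` is one of three compounds sharing a core and measured in an ADME assay on cells (Hepatocyte, Rattus norvegicus) for metabolic stability; a higher number here means faster removal of the compound, a lower number slower removal; compound 3 gives 10 uL/min, compound 1 `Cc1ccc2[nH]c(C(=O)N[C@H]3CCN(S(=O)(=O)N4CCCCC4)C[C@@H]3C(=O)NCCN(C)C)cc2c1` gives 25 uL/min and compound 2 `Cc1ccc2[nH]c(C(=O)N[C@H]3CCN(S(=O)(=O)N4CCOCC4)C[C@@H]3C(=O)NCCN(C)C)cc2c1` gives 6 uL/min. Compound 3 stands second highest, with a 1.7-fold higher number from compound 2 to compound 3 (0.22 log units; within the scatter) and a 2.5-fold lower number from compound 1 to compound 3 (0.40 log units; beyond the scatter); the remaining step is a 4.2-fold lower number from compound 1 to compound 2 (0.62 log units; beyond the scatter). Compound 4 `Cc1ccc2[nH]c(C(=O)N[C@H]3CCN(C(=O)c4cccnc4)C[C@@H]3C(=O)NCCN(C)C)cc2c1` differs from compound 3 by (pyridin-3-yl)carbonyl in place of dimethylsulfamoyl on an amine nitrogen in a ring. Within the data shown here, none of the measured steps touches a carbonyl in this place, so no step bears directly on the change, and the whole spread of the three numbers is modest. Compound 4 is therefore expected to show a small step, a 1.2-fold higher number from compound 3 to compound 4 (0.08 log units; within the scatter), in either direction. The value of compound 4 in this assay is estimated at 12 uL/min, within 5 uL/min to 30 uL/min.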

Compound 4, intrinsic clearance in a liver preparation (reported as CLH), per the amount of preparation that the assay uses: 6 uL/min
Compound 4: middle estimate off by 2.0-fold (0.30 log units), on the high side; the range from low to high includes it.
By their numbers in this assay, from the lowest: compounds 2, 4 and 3 (each within the scatter of the next); then compound 1.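

In this assay, a carbonyl at this place, carrying an aromatic ring, cannot be told apart from two of the sulfonyl groups (a 1.7-fold lower number from compound 3 to compound 4 (0.22 log units; within the scatter) and no change at the digits printed from compound 2 to compound 4 (within the scatter)), while (piperidin-1-yl)sulfonyl stays apart from it (a 4.2-fold lower number from compound 1 to compound 4 (0.62 log units; beyond the scatter)). Thus the higher number of compound 1 belongs to that one group, not to every large group on this amine nitrogen. Nothing measured here explains these steps. Still open, from the compounds shown here alone, is whether the pyridine nitrogen matters, which a benzoyl group would test, and whether a carbonyl without an aromatic ring, such as acetyl, gives a similar number.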